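Series notes: methyl, 1-hydroxyethyl, methoxy on the aromatic carbon

A few compounds are considered here, and "the series" means these few. Any claim that something is new, unique, unknown or untested is made for them only; others in the source may bear on it.

Compound 1 `Cc1cnc(N2CCC(c3coc4c(N5CCc6cc(S(C)(=O)=O)ccc65)ncnc34)CC2)nc1` carries a methyl on an aromatic carbon; in a functional assay on cells for agonist activity at Glucose-dependent insulinotropic receptor (Homo sapiens), read by a luciferase reporter, with a stated time of 4 h (on this read-out lower numbers stand for smaller maximal responses and higher numbers for larger maximal responses), compound 1 reaches 159%. Going by the values given here, compound 2 `CC(O)c1cnc(N2CCC(c3coc4c(N5CCc6cc(S(C)(=O)=O)ccc65)ncnc34)CC2)nc1` carries a 1-hydroxyethyl on that aromatic carbon instead; in this assay compound 2 reaches 33%, the lowest of the two numbers so far, with compound 1 as its only neighbour. Among the compounds with values here, the step of a number 126 percentage points lower from compound 1 to compound 2 (beyond the scatter) is the one measured change. Compound 3 `COc1cnc(N2CCC(c3coc4c(N5CCc6cc(S(C)(=O)=O)ccc65)ncnc34)CC2)nc1` is not yet measured and differs from compound 2 as follows: methoxy in place of 1-hydroxyethyl on an aromatic carbon. Within the data shown here, the measured step bears on this only in part: the 1-hydroxyethyl that entered from compound 1 to compound 2 now leaves, but methoxy rather than methyl enters, and no methoxy analogue has been measured here. In this assay compound 3 is therefore expected at 110%, within 40% to 170%. The expected step is a number 77 percentage points higher from compound 2 to compound 3 (beyond the scatter), upward and beyond the scatter, with wide uncertainty.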

Compound 3, largest response reached (Emax), in percent of the reference or control that the assay uses: 186%
Estimate against measurement, compound 3: 76 percentage points below; the whole stated range lies below it.
By their numbers in this assay, from the lowest: compound 2; then compound 1; then compound 3.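

In this assay the position on the pyrimidine ring, para to a large group, gives very different results with two oxygen-bearing groups: methoxy in place of 1-hydroxyethyl gives a number 153 percentage points higher from compound 2 to compound 3 (beyond the scatter), and methoxy in place of methyl gives a number 27 percentage points higher from compound 1 to compound 3 (beyond the scatter). An oxygen attached at this aromatic carbon therefore does not itself lower the maximal response, and the low value belongs to 1-hydroxyethyl alone among the three groups, while methoxy exceeds even the methyl reference point of the series. No available evidence bears on what lies behind these differences.

Still open, from the compounds shown here alone, is whether the low response of compound 2 goes with the hydroxyl or with the two-carbon chain that carries it. An ethyl and a hydroxymethyl at this position would separate the two, and an ethoxy would show whether the methoxy result extends to a longer chain.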